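Chloro in Place of Ethoxy on the Anilino Ring

A few compounds are considered here, and "the series" means these few. Any claim that something is new, unique, unknown or untested is made for them only; others in the source may bear on it.

compound 1 `CCCCCOC1=C(C(=O)c2ccccc2)C(c2ccc(Br)cc2)N(CCCn2ccnc2)C1=O` in a functional assay on SAOS-2 cells (Homo sapiens) for antiproliferative activity, read by MTT assay, with a stated time of 72 h; a lower number here means a stronger inhibitor, a higher number a weaker inhibitor: 9990 nM
compound 2 `CCOc1ccc(NC2=C(C(=O)c3ccccc3)C(c3ccc(Br)cc3)N(CCCn3ccnc3)C2=O)cc1` in this assay: 30900 nM

Among the measured compounds shown here, compound 2 stands highest of the two numbers; the only measured step, a 3.1-fold higher number from compound 1 to compound 2 (0.49 log units; beyond the scatter), runs toward it. Compound 3 `O=C(C1=C(Nc2ccc(Cl)cc2)C(=O)N(CCCn2ccnc2)C1c1ccc(Br)cc1)c1ccccc1` differs from compound 2 by chloro in place of ethoxy on an aromatic carbon. For the measured compounds named here, no measured step touches a group on that aromatic ring, so the step from compound 1 to compound 2, which exchanges pentyloxy for (4-ethoxyphenyl)amino, gives no guidance here. With no direction indicated, compound 3 is expected to land close to compound 2. For compound 3 the expected step is a 1.2-fold lower number from compound 2 to compound 3 (0.09 log units; within the scatter), within the scatter. The estimate for compound 3 is 25000 nM, between 8000 nM and 80000 nM.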

Compound 3, half-maximal inhibitory concentration: 24800 nM
Compound 3: middle estimate off by 1.0-fold (0.00 log units), on the high side; low and high end bracket the measured number.
By their numbers in this assay, from the lowest: compound 1; then compounds 3 and 2 (each within the scatter of the next).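

In this assay, swapping the ethoxy on the aromatic ring for chloro makes no difference that can be told from scatter (a 1.2-fold lower number from compound 2 to compound 3 (0.10 log units; within the scatter)), so this ring position tolerates both groups in these two compounds. The change at the double-bonded ring carbon also holds with the new ring group, in the same direction as before (a 2.5-fold higher number from compound 1 to compound 3 (0.39 log units; beyond the scatter)). No measurement here explains either result.

Still open, on these data alone, is whether a different group at this ring position, such as an amine or a carboxylic acid, would move the number. A longer chain in place of ethoxy is equally unresolved.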